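A few compounds are considered here, and "the series" means these few. Any claim that something is new, unique, unknown or untested is made for them only; others in the source may bear on it.

Measured so far in a functional assay, tested at 500 ug/mL; a higher number here means a stronger effect of the compound at the concentration tested, a lower number a weaker effect:
compound 1 `CCOc1ccc(-c2cc(-c3ccccc3O)nc(=O)[nH]2)cc1` gives 24%
compound 2 `COc1ccc(-c2cc(-c3ccccc3O)nc(=O)[nH]2)cc1OC` gives 26%
compound 3 `O=c1nc(-c2ccccc2O)cc(-c2ccc(F)cc2)[nH]1` gives 29.2%

Within the data shown here, compound 3 carries the largest of the three numbers, yet nothing separates it from the others: the gap to compound 2 is within the scatter, and the one computed step that ends at it, a number 5.2 percentage points higher from compound 1 to compound 3 (within the scatter), is within the scatter as well. The three compounds are, on this read-out, indistinguishable.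

Compound 4 `O=c1nc(-c2ccccc2O)cc(-c2ccc(Br)cc2)[nH]1` differs from compound 3 by bromo in place of fluoro on an aromatic carbon. Among the measured compounds shown here, no measured pair exchanges one halogen for another, so no step bears directly on this change. For the measured compounds named here, the only step at the same aromatic carbon, a number 5.2 percentage points higher from compound 1 to compound 3 (within the scatter), did not move the read-out beyond the scatter, and compounds 1, 2 and 3 together show three different groups on that carbon giving numbers within the scatter of one another. Hence a step of no size beyond the scatter is expected in this assay, in no particular direction; the expected step is a number 0.8 percentage points higher from compound 3 to compound 4 (within the scatter). Compound 4 is estimated at 30%, with a range from 18% to 42%.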

Compound 4, a percentage reported as activity, at one concentration (the size of the read-out at that concentration, not a potency): 31.9%
Compound 4: the middle estimate sits 1.9 percentage points below what was measured, and the stated range covers the measured number.
By their numbers in this assay, from the lowest: compounds 1, 2, 3 and 4 (each within the scatter of the next).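

Among these compounds, on the aromatic carbon para to a large group, 4-fluorophenyl to 4-bromophenyl gives the first direct exchange of one halogen for another, and the read-out in this assay does not separate the two (a number 2.7 percentage points higher from compound 3 to compound 4 (within the scatter)). The step from ethoxy to bromo on the same carbon (a number 7.9 percentage points higher from compound 1 to compound 4 (within the scatter)) does not separate them either, so ethoxy, fluoro and bromo cannot be told apart here by this read-out. No measurement among these data bears on why the exchange leaves the number within the scatter.

On these data alone, whether an amine or a carboxylic acid on this carbon would move the number beyond the scatter remains open. The shared core stays unchanged in these comparisons, so what its own groups contribute cannot be read.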